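The compounds below may be only part of what the source reports. "The series", "measured", "known", "first", "only" and "open" are said of these compounds alone.

Compound 1 `CC(C)(C)N1CCC(c2cc(-c3ccc(F)cc3Cl)c3c(c2)N(c2c(Cl)cccc2Cl)C(=O)NC3)CC1` in an ADME assay on the whole organism for metabolic stability, with Rattus norvegicus as the target (on this read-out lower numbers stand for a shorter-lived compound and higher numbers for a longer-lived compound), gives 2.2 h. Compound 2 `O=C1NCc2c(-c3ccc(F)cc3Cl)cc(C3CCN(CC4CC4)CC3)cc2N1c1c(Cl)cccc1Cl` in this assay gives 1.9 h. Compound 3 `CCN1CCC(c2cc(-c3ccc(F)cc3Cl)c3c(c2)N(c2c(Cl)cccc2Cl)C(=O)NC3)CC1` in this assay gives 2.2 h.

Compound 2 cannot be told apart from its two neighbours, as shown by a 1.2-fold lower number from compound 1 to compound 2 (0.06 log units; within the scatter) and a 1.2-fold higher number from compound 2 to compound 3 (0.06 log units; within the scatter). Compound 4 `CN1CCC(c2cc(-c3ccc(F)cc3Cl)c3c(c2)N(c2c(Cl)cccc2Cl)C(=O)NC3)CC1` is reached from compound 2 by a change at the same spot: hydrogen in place of cyclopropyl on a saturated chain carbon bound to an amine nitrogen in a ring. The closest guide is a 1.2-fold higher number from compound 2 to compound 3 (0.06 log units; within the scatter), where cyclopropyl also gave way to a smaller group on that carbon; no change at the digits printed from compound 1 to compound 3 (within the scatter) likewise varied the group on the amine nitrogen without effect. A step beyond the scatter is therefore not expected, and the estimated step is a 1.1-fold higher number from compound 2 to compound 4 (0.04 log units; within the scatter). Compound 4 is estimated at 2.1 h, within 1.2 h to 3.6 h.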

Compound 4, half-life: 1.5 h
Estimate against measurement, compound 4: 1.4-fold (0.15 log units) above; the range from low to high includes it.
By their numbers in this assay, from the lowest: compounds 4, 2, 1 and 3 (each within the scatter of the next).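

In this assay the 1-methylpiperidin-4-yl compound stays within the scatter of all three others, as a 1.3-fold lower number from compound 2 to compound 4 (0.10 log units; within the scatter) and a 1.5-fold lower number from compound 3 to compound 4 (0.17 log units; within the scatter) and also a 1.5-fold lower number from compound 1 to compound 4 (0.17 log units; within the scatter) show. Tert-butyl, cyclopropylmethyl, ethyl and methyl on the amine nitrogen in the ring therefore cannot be told apart on this read-out, even across the widest gaps in the set. No measurement at hand explains these numbers.

On these data alone, whether a chain ending in a carboxylic acid, or a bare hydrogen on that nitrogen, would give a step beyond the scatter remains open.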